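Swapping a Pyridyl Tail for a Cyanobenzyl Tail

The compounds below may be only part of what the source reports. "The series", "measured", "known", "first", "only" and "open" are said of these compounds alone.

Compound 1 `CC(=O)N1CCC(C(=O)N(CCCN2CCC(Oc3ccccc3)CC2)c2ccc(C)c(Cl)c2)CC1` gives > 56600 nM in an ADME assay (Homo sapiens) for cytotoxicity (on this read-out higher numbers stand for lower toxicity in this test and lower numbers for higher toxicity in this test), which is a limit of the test rather than a number.
Compound 2 `CC(=O)N1CCC(C(=O)N(CCCN2CCN(Cc3cccnc3)CC2)c2ccc(C)c(Cl)c2)CC1` gives > 56700 nM in this assay, again a limit rather than a number.

Going by the values given here, compound 2 therefore stands only at a limit, and the one other value shown is a limit as well: the limit of > 56600 nM in this assay, at which 1 of the 2 values shown sits, and (the limit of > 56700 nM in this assay, at which 1 of the 2 values shown sits). Neither compound reached measurable toxicity in this test.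

Compound 3 `CC(=O)N1CCC(C(=O)N(CCCN2CCN(Cc3ccc(C#N)cc3)CC2)c2ccc(C)c(Cl)c2)CC1` is not yet measured. It differs from compound 2 in one place: 4-cyanophenyl in place of pyridin-3-yl on a saturated chain carbon bound to an amine nitrogen in a ring. Among the compounds with values here, no step between measured compounds is available, so the expectation rests on the two limits alone. The expected step that the limit leaves unreadable from compound 2 to compound 3 from compound 2 to compound 3 is none beyond the usual scatter. Compound 3 is estimated at 60000 nM, with a range from 30000 nM to 120000 nM, most likely reported once more as a limit.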

Compound 3, half-maximal cytotoxic concentration: > 100000 nM
Compound 3 was reported as a limit; the forecaster's own chance of this, stated with the estimate: 80%; at least 1.6-fold (0.22 log units) between middle value and limit.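

Compound 2 and compound 3 both stand only at limits in this assay, and the step between them cannot be read. The compounds shown leave open at what concentration any of them turns cytotoxic, and whether 4-cyanophenyl in place of pyridin-3-yl shifts that concentration.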